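From methyl to 4-ethylpiperazin-1-yl on compound 2

The compounds below may be only part of what the source reports. "The series", "measured", "known", "first", "only" and "open" are said of these compounds alone.

Measured in a functional assay on MDA-MB-231 cells (Homo sapiens) for inhibition, read by CCK-8 assay, with a stated time of 48 h; a higher number here means a weaker inhibitor of growth, a lower number a stronger inhibitor of growth:
compound 1 `Cc1ccccc1Nc1nc(NC2CC2)ncc1Cl`: > 100000 nM (a limit)
compound 2 `Cc1ccc(Nc2ncc(Cl)c(Nc3ccccc3C)n2)cc1`: > 100000 nM (a limit)
compound 3 `Cc1ccccc1Nc1nc(Nc2cc(Cl)ccn2)ncc1Cl`: 52400 nM

Compound 2 has no number of its own in this assay. It sits at the limit of > 100000 nM in this assay, at which 2 of the 3 values shown sit. The next structure, compound 4 `CCN1CCN(c2ccc(Nc3ncc(Cl)c(Nc4ccccc4C)n3)cc2)CC1`, replaces its methyl with a 4-ethylpiperazin-1-yl group on an aromatic carbon: 4-ethylpiperazin-1-yl in place of methyl on an aromatic carbon.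

Among the compounds with values here, no measured step makes this exchange. The nearest steps replace the whole group on a nitrogen. One is a step that the two limits leave unreadable from compound 1 to compound 2, which gives no size. The other is an at least 1.9-fold lower number from compound 2 to compound 3 (0.28 log units; that floor lies within the scatter), whose floor does not clear the scatter. Within the data shown here, compound 3, at 52400 nM, shows only that a change to that group can bring a readable number on the shared core. The size of the coming step therefore rests on judgement, and the estimate is wide.

A lower number is expected, and the estimated step is an at least 8.3-fold lower number from compound 2 to compound 4 (0.92 log units; beyond the scatter). For compound 4 the expected value is 12000 nM, with an estimated range from 2000 nM to 70000 nM.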

Compound 4, concentration for 50% growth inhibition: 3040 nM
For compound 4 the middle estimate is 3.9-fold (0.60 log units) above the measured one; low and high end bracket the measured number.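

In this assay, exchanging methyl for 4-ethylpiperazin-1-yl on the aromatic carbon para to a large group gives an at least 32-fold lower number from compound 2 to compound 4 (1.51 log units; beyond the scatter). Unlike the steps that replace the whole group on a nitrogen, this one clears the scatter, so this position on the ring can change the growth read-out by a readable margin. Even so, the step gives only a floor and not a full size, because compound 2 carries only a limit: the limit of > 100000 nM in this assay, at which 2 of the 4 values shown sit.

The compounds shown do not separate the effect of the six-membered ring from that of its ethyl group, so it stays open whether a piperazin-1-yl group without the ethyl or a morpholin-4-yl group would behave alike at this position. They also leave open whether the ring is needed at all, which an open-chain amine such as dimethylamino in the same place would address.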